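Fluoro in Place of Methyl: What to Expect of Compound 4

This account rests on a few compounds, and the source may have more. Where it says the series, first, only, none or still open, it means among the compounds named here.

Compound 1 `Cc1ccccc1-c1cccc(NC(=O)C(Cl)Cl)c1` gives 31600 nM in a functional assay on NCI-H460 cells (Homo sapiens) for cytotoxicity, read by MTT assay, with a stated time of 68 h; a lower number here means a stronger inhibitor, a higher number a weaker inhibitor. Compound 2 `O=C(Nc1cccc(-c2ccccc2F)c1)C(Cl)Cl` gives 26800 nM in this assay. The change between them is fluoro in place of methyl on an aromatic carbon, and it made a step of a 1.2-fold lower number from compound 1 to compound 2 (0.07 log units; within the scatter). Compound 3 `Cc1ccc(-c2cccc(NC(=O)C(Cl)Cl)c2)cc1` gives 8000 nM in this assay; how its core differs from that of compound 1 is not broken down here. Compound 4 `O=C(Nc1cccc(-c2ccc(F)cc2)c1)C(Cl)Cl` has not yet been measured and differs from compound 3 by fluoro in place of methyl on an aromatic carbon. This is the same kind of change as that from compound 1 to compound 2, though not the same: there the place was ortho to a large group, here it is para to a large group. Since the step of a 1.2-fold lower number from compound 1 to compound 2 (0.07 log units; within the scatter) stayed within the scatter, the step of a 1.1-fold lower number from compound 3 to compound 4 (0.06 log units; within the scatter) is expected to be similarly small. Compound 4 is accordingly estimated at 7000 nM, between 3000 nM and 16000 nM.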

Compound 4, half-maximal inhibitory concentration: > 50000 nM
Compound 4 was reported as a limit (the forecaster's own chance of this, stated with the estimate: 3%); middle value at least 7.1-fold (0.85 log units) away from the limit.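

Fluoro in place of methyl gave an at least 6.2-fold higher number from compound 3 to compound 4 (0.79 log units; beyond the scatter) in this assay, so a small step on one core did not predict the step on the other: the same change on two cores in this assay, a 1.2-fold lower number (0.07 log units; within the scatter) from compound 1 to compound 2 and an at least 6.2-fold higher number (0.79 log units; beyond the scatter) from compound 3 to compound 4, at least 7.3-fold (0.86 log units) apart, beyond the scatter of two such steps. Compound 4 is reported only as a limit of the assay, which leaves the full size of its step unknown: the limit of > 50000 nM in this assay, at which 1 of the 4 values shown sits. Core and place both differ between the two pairs, and these compounds do not show which of the two matters.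

On these data alone, whether the change would behave the same way at a third place on this ring remains open. So does how a methoxy group or an amine would read in this assay when para to a large group.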